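A few compounds are considered here, and "the series" means these few. Any claim that something is new, unique, unknown or untested is made for them only; others in the source may bear on it.

Compound 2 `Cc1ccc(-n2nc(C(=O)Nc3ccc(Oc4ncnc5sccc45)cc3)c(C)cc2=O)cc1` belongs to a small series on the shared core of compound 1 `Cc1cc(=O)n(-c2ccccc2OC(F)(F)F)nc1C(=O)Nc1ccc(Oc2ncnc3sccc23)cc1`. In a functional assay on HepG2 cells (Homo sapiens) for cytotoxicity, read by MTT assay, with a stated time of 72 h (on this read-out higher numbers stand for weaker inhibition and lower numbers for stronger inhibition), compound 1 gives 14400 nM. In this assay compound 2 gives a limit of the assay, > 40000 nM, and no number. The step of an at least 2.7-fold higher number from compound 1 to compound 2 (0.44 log units; beyond the scatter) thus rests on (the limit of > 40000 nM in this assay, at which 1 of the 2 values shown sits). Compound 3 `Cc1cc(=O)n(-c2ccc(F)c(F)c2)nc1C(=O)Nc1ccc(Oc2ncnc3sccc23)cc1` differs from compound 2 by 3,4-difluorophenyl in place of 4-methylphenyl on an aromatic nitrogen. Within the data shown here, only the step from compound 1 to compound 2 bears on this change, and it was at least modest but bounded by the limit. The expected step is an at least 1.3-fold lower number from compound 2 to compound 3 (0.12 log units; that floor lies within the scatter), with a fair chance that only a limit is seen again. Compound 3 is expected near 30000 nM, between 10000 nM and 90000 nM.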

Compound 3, half-maximal inhibitory concentration: 16800 nM
The estimate for compound 3 lay 1.8-fold (0.25 log units) above the measured number; the measured number falls inside the stated range.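

On the aromatic nitrogen, 3,4-difluorophenyl in place of 4-methylphenyl gives in this assay an at least 2.3-fold lower number from compound 2 to compound 3 (0.37 log units; beyond the scatter). In place of 2-(trifluoromethoxy)phenyl, the same group gives a 1.2-fold higher number from compound 1 to compound 3 (0.07 log units; within the scatter), so among the three compounds only 4-methylphenyl stands apart. The first step gives a floor and not a full size, as compound 2 has only a limit of the assay: the limit of > 40000 nM in this assay, at which 1 of the 3 values shown sits.

As far as these compounds go, whether a fluorine pattern matters here stays open, as does the reading for unsubstituted phenyl. A phenyl ring carrying an amine or a carboxylic acid is also untested in the compounds shown.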